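Adding isopropyl to the hydroxyethyl amide series

This account rests on a few compounds, and the source may have more. Where it says the series, first, only, none or still open, it means among the compounds named here.

Within the data shown here, in a functional assay on PC-3 cells (Homo sapiens) for antiproliferative activity, read by MTT assay, with a stated time of 24 h (a lower number here means a stronger inhibitor, a higher number a weaker inhibitor), compound 2 `CCn1c(C(=O)NCCO)ccc1C(CC)(CC)c1ccc(OCS(=O)(=O)c2ccccc2)c(C)c1` gives 17700 nM, the only numerical value so far. Compound 1 `CCn1c(C(=O)N[C@@H](C)C(=O)OC)ccc1C(CC)(CC)c1ccc(OCS(=O)(=O)c2ccccc2)c(C)c1` is reported only as a limit, > 50000 nM. Among the measured compounds shown here, the one measured step is an at least 2.8-fold lower number from compound 1 to compound 2 (0.45 log units; beyond the scatter), with 2-hydroxyethyl in place of 1-(methoxycarbonyl)ethyl on an amide-type nitrogen. Its size is open on one side, since one end is a limit.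

Compound 3 `CCn1c(C(=O)N[C@@H](CO)C(C)C)ccc1C(CC)(CC)c1ccc(OCS(=O)(=O)c2ccccc2)c(C)c1` is next, with the change isopropyl in place of hydrogen on a saturated chain carbon bound to an amide-type nitrogen and a saturated chain carbon. The 2-hydroxyethyl group thus becomes 1-(hydroxymethyl)-2-methylpropyl. The measured step concerns the same amide-type nitrogen substituent but does not test isopropyl, so it is only a weak guide. Its direction, an at least 2.8-fold lower number from compound 1 to compound 2 (0.45 log units; beyond the scatter), suggests that compound 3 may read slightly higher in this assay, though no shift beyond the scatter is expected. The expected change is a 1.2-fold higher number from compound 2 to compound 3 (0.07 log units; within the scatter). For compound 3 the estimated value is 21000 nM, with an expected range of 8000 nM to 50000 nM.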

Compound 3, half-maximal inhibitory concentration: 10600 nM
Compound 3: the middle estimate sits 2.0-fold (0.30 log units) above what was measured; the measured number falls inside the stated range.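

In this assay, isopropyl in place of hydrogen on the saturated chain carbon bound to the amide-type nitrogen gives a 1.7-fold lower number from compound 2 to compound 3 (0.22 log units; within the scatter), so this position accepts the isopropyl group with no shift beyond the scatter. The 1-(hydroxymethyl)-2-methylpropyl group in place of 1-(methoxycarbonyl)ethyl gives an at least 4.7-fold lower number from compound 1 to compound 3 (0.67 log units; beyond the scatter), which makes compound 3 the second compound with a hydroxyl-bearing substituent on this nitrogen to read clearly lower than the methyl ester compound 1, and neither of the two goes against this within the three compounds shown. Compound 1 is reported only as a limit, so this step is open on one side: the limit of > 50000 nM in this assay, at which 1 of the 3 values shown sits.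

The compounds shown leave open whether a methyl, a longer chain or a benzyl group on the same chain carbon would read differently from isopropyl, and whether the opposite configuration at that carbon would matter. Going by these compounds, it also remains open whether the hydroxyl itself separates compound 2 and compound 3 from compound 1, a question that a methyl ether, an amine or a carboxylic acid in its place could address.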